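The compounds below may be only part of what the source reports. "The series", "measured", "known", "first", "only" and "open" are said of these compounds alone.

Measured compounds: compound 1 `CCCCc1c(OC)nc2nc(C(=O)c3ccccc3)cn2c1CC` gives 10 mg/kg in a functional assay on the whole organism with Rattus norvegicus as the target; on this read-out lower numbers stand for an effect already at smaller amounts and higher numbers for an effect only at larger amounts of compound; compound 2 `CCCc1cc(SC)nc2nc(C(=O)c3ccccc3)cn12` gives 10 mg/kg; compound 3 `CCc1c(OC)nc2nc(C(=O)c3ccccc3)cn2c1CC` gives 2 mg/kg.

Compound 1 and compound 2 differ in their cores, and that difference is not broken down here; their values in this assay are within the scatter of each other. Compound 3 arises from compound 1 by hydrogen in place of ethyl on a saturated chain carbon, two bonds along the chain from an aromatic carbon, and this gave a 5.0-fold lower number from compound 1 to compound 3 (0.70 log units; beyond the scatter). Compound 4 `CSc1cc(C)n2cc(C(=O)c3ccccc3)nc2n1` is not yet measured. It arises from compound 2 by hydrogen in place of ethyl on a saturated chain carbon bound to an aromatic carbon, the same kind of change, though the place differs: bound to an aromatic carbon rather than two bonds along the chain from an aromatic carbon, and on a different core. Because a 5.0-fold lower number from compound 1 to compound 3 (0.70 log units; beyond the scatter) was beyond the scatter, a lower number is expected for compound 4 as well, though more cautiously given the different place, so the estimated step is a 2.5-fold lower number from compound 2 to compound 4 (0.40 log units; beyond the scatter). Compound 4 is estimated at 4 mg/kg, between 1.5 mg/kg and 12 mg/kg.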

Compound 4, minimum effective dose: 5 mg/kg
The estimate for compound 4 lay 1.3-fold (0.10 log units) below the measured number, within the range that was stated.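

In this assay, hydrogen in place of ethyl on a saturated chain carbon bound to an aromatic carbon gave a 2.0-fold lower number from compound 2 to compound 4 (0.30 log units; within the scatter). Set beside the step on the core of compound 1, this result gives no sign that the core alters the size of the step: the same change on two cores in this assay, a 5.0-fold lower number (0.70 log units; beyond the scatter) from compound 1 to compound 3 and a 2.0-fold lower number (0.30 log units; within the scatter) from compound 2 to compound 4, 2.5-fold (0.40 log units) apart, within the scatter of two such steps This does not show that the change carries over unaltered, since only two pairs are available, the place on the chain differs between them, and the step on the core of compound 2 cannot, on its own, be told from the scatter.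

The compounds shown leave open how a longer chain than propyl would behave on either core. They also leave open what an amine or a carboxylic acid at the end of that chain would do.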